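The source may report more compounds than this note shows. Statements on the series, on what has been measured and on what is new or still open speak of the compounds shown alone.

In a functional assay on PC-3 cells (Homo sapiens) for antiproliferative activity, read by MTT assay, with a stated time of 24 h (on this read-out lower numbers stand for stronger inhibition and higher numbers for weaker inhibition), three amides sharing one core have been measured. Compound 1 (`CCn1c(C(=O)N[C@@H](C)CO)ccc1C(CC)(CC)c1ccc(OCS(=O)(=O)c2ccccc2)c(C)c1`) gives 9520 nM, compound 2 (`CCn1c(C(=O)N[C@H](CO)C(C)C)ccc1C(CC)(CC)c1ccc(OCS(=O)(=O)c2ccccc2)c(C)c1`) gives 7300 nM, and compound 3 (`CCn1c(C(=O)NCCCO)ccc1C(CC)(CC)c1ccc(OCS(=O)(=O)c2ccccc2)c(C)c1`) gives 11300 nM. Compound 3 thus stands within the scatter of both others, with a 1.2-fold higher number from compound 1 to compound 3 (0.07 log units; within the scatter) and a 1.5-fold higher number from compound 2 to compound 3 (0.19 log units; within the scatter). The next compound, compound 4 (`CCn1c(C(=O)N[C@@H](C)C(=O)O)ccc1C(CC)(CC)c1ccc(OCS(=O)(=O)c2ccccc2)c(C)c1`), carries 1-carboxyethyl in place of 3-hydroxypropyl on an amide-type nitrogen. The measured steps that bear on this change all concern the group on that same nitrogen, and the remaining one, a 1.3-fold lower number from compound 1 to compound 2 (0.12 log units; within the scatter), also stays within the scatter. Going by the values given here, none of the measured compounds carries 1-carboxyethyl, however, so these steps offer only indirect guidance. No step beyond the scatter is therefore expected in this assay, though the uncertainty is wide. The expected change is a 1.1-fold higher number from compound 3 to compound 4 (0.03 log units; within the scatter). The estimate for compound 4 is 12000 nM, with an expected range from 4500 nM to 35000 nM.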

Compound 4, half-maximal inhibitory concentration: 16800 nM
The estimate for compound 4 lay 1.4-fold (0.15 log units) below the measured number, within the range that was stated.
By their numbers in this assay, from the lowest: compounds 2, 1, 3 and 4 (each within the scatter of the next, the first and the last beyond it).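

In this assay, carboxy in place of hydroxymethyl on the saturated chain carbon gives a 1.8-fold higher number from compound 1 to compound 4 (0.25 log units; within the scatter) and 1-carboxyethyl in place of 3-hydroxypropyl gives a 1.5-fold higher number from compound 3 to compound 4 (0.17 log units; within the scatter), so neither replacement moves the read-out beyond the scatter. Against compound 2, however, 1-carboxyethyl in place of 1-(hydroxymethyl)-2-methylpropyl gives a 2.3-fold higher number from compound 2 to compound 4 (0.36 log units; beyond the scatter), the first step on this amide-type nitrogen to pass the scatter, though only modestly. Nothing available explains this difference.

The compounds shown leave open whether a methyl ester or a primary amine in place of the carboxy would stay in this same range. They also leave open what a longer chain carrying the carboxylic acid on this nitrogen, or an isopropyl in place of the methyl of 1-carboxyethyl, would give.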